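A few compounds are considered here, and "the series" means these few. Any claim that something is new, unique, unknown or untested is made for them only; others in the source may bear on it.

Compound 1, `O=C(C1CCN(S(=O)(=O)c2ccc3[nH]ncc3c2)CC1)N(CCO)Cc1ccccc1C(F)(F)F`, gives 60% in a functional assay on CHO cells for positive allosteric modulation of muscarinic acetylcholine receptor M5 (Homo sapiens), read by calcium flux; a higher number here means a larger maximal response, a lower number a smaller maximal response.
Compound 2, `CCC(C)N(Cc1ccccc1C(F)(F)F)C(=O)C1CCN(S(=O)(=O)c2ccc3[nH]ncc3c2)CC1`, gives 100% in this assay.

Among the two measured compounds, compound 2 stands at the top: the step of a number 40 percentage points higher from compound 1 to compound 2 (beyond the scatter) is the only one shown, and it lies well beyond the scatter. That step exchanged, on the amide-type nitrogen, a 2-hydroxyethyl for a sec-butyl.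

Compound 3, `O=C(C1CCN(S(=O)(=O)c2ccc3[nH]ncc3c2)CC1)N(Cc1ccccc1C(F)(F)F)CC1CC1`, is not yet measured. Its difference from compound 2 is cyclopropylmethyl in place of sec-butyl on an amide-type nitrogen. Among the measured compounds shown here, the one step that bears on this position, a number 40 percentage points higher from compound 1 to compound 2 (beyond the scatter), was large, but it compared a chain carrying a hydroxyl with a plain sec-butyl. The change to compound 3 keeps a group of the same size and the same element count at the same nitrogen, and nothing in the measured pair shows what such a swap does. The expectation is therefore a step that stays within or close to the scatter, a number 10 percentage points lower from compound 2 to compound 3 (within the scatter). For compound 3 in this assay the estimate is 90%, in a range from 65% to 110%.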

Compound 3, largest response reached (reported as percent of maximum), in percent of the reference or control that the assay uses: 102%
Compound 3: the middle estimate sits 12 percentage points below what was measured, and the stated range covers the measured number.
By their numbers in this assay, from the lowest: compound 1; then compounds 2 and 3 (each within the scatter of the next).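

In this assay, the step is a number 2 percentage points higher from compound 2 to compound 3 (within the scatter), so sec-butyl and cyclopropylmethyl, which have the same count of heavy atoms, cannot be told apart at this amide-type nitrogen, even though only cyclopropylmethyl holds a ring. The comparison with the hydroxyl-bearing compound, a number 42 percentage points higher from compound 1 to compound 3 (beyond the scatter), is large, which shows that the high response seen earlier with sec-butyl is not unique to that group: among the three compounds shown, both groups made only of carbon and hydrogen stand well above the 2-hydroxyethyl of compound 1. No measurement available here gives a reason for either the large step or the small one.

The compounds shown leave open whether a longer chain such as n-hexyl, a benzyl group, or a chain carrying an amine or a carboxylic acid at this nitrogen would stay level with compound 2 and compound 3 or drop toward compound 1. Among the compounds shown here, with compound 1 as the only example of a lower response, they also cannot show whether a 2-methoxyethyl chain, which has an oxygen but no hydroxyl, would behave like 2-hydroxyethyl.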